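A few compounds are considered here, and "the series" means these few. Any claim that something is new, unique, unknown or untested is made for them only; others in the source may bear on it.

Measured so far in this series:
compound 1, `COc1ccc(N2C(=O)CSC2c2sc(-c3ccccc3)nc2C)cc1`: 48.2%
compound 2, `Cc1ccc(N2C(=O)CSC2c2sc(-c3ccc(Cl)cc3)nc2C)cc1`: 37.6%

In a functional assay on the whole organism (strain Wistar albino) for inhibition, with Rattus norvegicus as the target, read by paw edema, with stated times of 1 h and 2 h, at a dose of 40 mg/kg by the oral route (a higher number here means more inhibition at the dose given (going by the name of the read-out), a lower number less inhibition), compound 1 gives 48.2%, while compound 2 gives 37.6%. Compound 2 stands lowest of the two numbers; its nearest neighbour is compound 1, whose number lies higher by a gap beyond the usual scatter. Going by the values given here, the two compounds differ in two places at once, so no single step between them can be read off, and the pair only shows that compound 1 sits clearly above compound 2.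

Compound 3, `COc1ccc(N2C(=O)CSC2c2sc(-c3ccc(Cl)cc3)nc2C)cc1`, has not yet been measured in this assay. Its difference from compound 2 is methoxy in place of methyl on an aromatic carbon. Compound 3 thus carries the same methoxy that compound 1 carries, while keeping the 4-chlorophenyl of compound 2. Among the compounds with values here, no measured pair shows this change alone, so the direction and size rest on a thin footing. Within the data shown here, a modest upward movement is expected, because compound 1, the only methoxy-bearing compound measured, gives 48.2%; yet the other difference between compounds 1 and 2 cannot be separated out, so no step beyond the scatter is anticipated. The step that this estimate means, a number 5.4 percentage points higher from compound 2 to compound 3 (within the scatter), is expected to stay within the scatter. In this assay compound 3 is estimated at 43%, with a range from 33% to 53%.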

Compound 3, a percentage reported as inhibition, in the whole organism at one dose (the size of the read-out at that dose, not a potency): 80.7%
Estimate against measurement, compound 3: 37.7 percentage points below; the whole stated range lies below it.
By their numbers in this assay, from the lowest: compound 2; then compound 1; then compound 3.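

Read alone for the first time, methoxy in place of methyl on an aromatic carbon, para to a large group, gives in this assay a number 43.1 percentage points higher from compound 2 to compound 3 (beyond the scatter), so the 4-methylphenyl to 4-methoxyphenyl change matters strongly here when the chloro is present. With the methoxy held constant, chloro in place of hydrogen on an aromatic carbon gives a number 32.5 percentage points higher from compound 1 to compound 3 (beyond the scatter), which shows that this second site also carries a large step. Compound 3, which combines the two groups, stands beyond the scatter above both compound 1 and compound 2, so neither group alone accounts for its number among these three compounds, and the earlier gap between compound 1 and compound 2 now reads as the net of two changes rather than as a simple methoxy gain.

Nothing available gives a reason for either step. Still open, on these data alone, are whether the methoxy step survives without the chloro, whether the chloro step survives with methyl in place of methoxy, and how an ethoxy, a hydroxyl or a dimethylamino group would read at the same para place.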